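From an Aromatic Ring to an Isopropyl on the Amide Nitrogen

The source may report more compounds than this note shows. Statements on the series, on what has been measured and on what is new or still open speak of the compounds shown alone.

Compound 1 `COc1ncc(-c2ccc3c(c2)N(c2ccc(C)cc2)C(=O)CO3)cc1NS(=O)(=O)c1ccc(F)cc1` gives 15400 nM in a functional assay on MCF7 cells (Homo sapiens) for antiproliferative activity, read by MTT assay, with a stated time of 72 h; a lower number here means a stronger inhibitor, a higher number a weaker inhibitor.
Compound 2 `O=C1COc2ccc(-c3cnc(Cl)c(NS(=O)(=O)c4ccc(F)cc4)c3)cc2N1c1ccc(F)cc1` gives 32600 nM in this assay.
Compound 3 `COc1ncc(-c2ccc3c(c2)N(c2ccc(F)cc2)C(=O)CO3)cc1NS(=O)(=O)c1ccc(F)cc1` reaches only a limit of the assay, > 40000 nM, in this assay.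

Among the two numbers reported, compound 2 stands highest, with compound 1 nearest at a lower number, while the figure for compound 3 is a limit, as noted in the limit of > 40000 nM in this assay, at which 1 of the 3 values shown sits. The measured steps are an at least 2.5-fold higher number from compound 1 to compound 3 (0.41 log units; beyond the scatter) and an at least 1.2-fold higher number from compound 2 to compound 3 (0.08 log units; that floor lies within the scatter); both concern the aromatic ring on the amide-type nitrogen or the group on the pyridine-like ring, not the exchange studied here. Compound 4 `CC(C)N1C(=O)COc2ccc(-c3cnc(Cl)c(NS(=O)(=O)c4ccc(F)cc4)c3)cc21` is not yet measured. It differs from compound 2 by isopropyl in place of 4-fluorophenyl on an amide-type nitrogen in a ring. Within the data shown here, no measured step speaks directly to this exchange, and every compound so far sits in the weak range of this assay. Compound 4 is therefore expected to remain weak, with an estimate of 30000 nM and a range from 8000 nM to 40000 nM. The step expected is a 1.1-fold lower number from compound 2 to compound 4 (0.04 log units; within the scatter), within the scatter, and a limit rather than a number would not surprise.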

Compound 4, half-maximal inhibitory concentration: 26600 nM
Beside the measured number, compound 4's estimate is 1.1-fold (0.05 log units) above it; the measured number falls inside the stated range.
By their numbers in this assay, from the lowest: compounds 1, 4 and 2 (each within the scatter of the next, the first and the last beyond it). At a limit, above all of these: compound 3.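

In this assay, the amide-type nitrogen in the ring carries two very different groups with no reading to separate them: isopropyl, with 3 heavy atoms and no ring, in place of 4-fluorophenyl, with 7 heavy atoms and a six-membered aromatic ring, gives a 1.2-fold lower number from compound 2 to compound 4 (0.09 log units; within the scatter). Among these compounds, all the earlier compounds kept an aromatic ring on this nitrogen and varied only its substituent or the group elsewhere on the core, so they could not show that the pair of compound 2 and compound 4 reads alike without that ring. The data shown offer no explanation for why this exchange leaves the number within the scatter.

Going by these compounds, whether any group on this nitrogen can move the number beyond the scatter remains open, for example a chain ending in an amine or a carboxylic acid, or a longer alkyl chain such as n-butyl. Also open, on these data alone, is whether isopropyl would read the same way on the methoxy-bearing compound 3, whose > 40000 nM is a limit of the assay and not a number.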